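This account rests on a few compounds, and the source may have more. Where it says the series, first, only, none or still open, it means among the compounds named here.

Working notes on the series. Compound 1 `CN(C(=O)NCCCOc1ccc2nc(O)ccc2c1)C1CCCCC1` is the reference point. In a functional assay on the whole organism for inhibition, with Mus musculus as the target, at a dose of 30 mg/kg by the oral route (a higher number here means more inhibition at the dose given (going by the name of the read-out), a lower number less inhibition), compound 1 gives 21%, the second highest of the three numbers in hand. Compound 3 `CN(C(=O)NCCCOc1ccc2nc(O)ccc2c1)[C@@H]1CCCC[C@H]1O` stands nearest: in this assay compound 3 gives 18%, and the step of a number 3 percentage points lower from compound 1 to compound 3 (within the scatter) comes from hydroxy in place of hydrogen on a saturated ring carbon. Compound 2 `O=C(NCCCOc1ccc2nc(O)ccc2c1)N(C1CCCCC1)C1CC1` stands furthest: in this assay compound 2 gives 100%, and the step of a number 79 percentage points higher from compound 1 to compound 2 (beyond the scatter) comes from cyclopropyl in place of methyl on an amide-type nitrogen.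

The next compound is compound 4 `CCN(CCCOc1ccc2nc(O)ccc2c1)C(=O)N(C)C1CCCCC1`. Against compound 1 the change is ethyl in place of hydrogen on an amide-type nitrogen. Neither measured step touches this position: the change from compound 1 to compound 2 sits on the other amide-type nitrogen, and the change from compound 1 to compound 3 sits on the saturated ring. The step from compound 1 to compound 2 shows that an alteration on an amide-type nitrogen of this core can move the read-out a long way, but it gives no direction for an ethyl at a nitrogen that carried hydrogen. Among the compounds with values here, with no step bearing on the change, the expectation is a step of a number 4 percentage points higher from compound 1 to compound 4 (within the scatter), within or close to the scatter, and a wide range. Compound 4 is expected to give 25% in this assay, estimated between 5% and 65%.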

Compound 4, a percentage reported as inhibition, in the whole organism at one dose (the size of the read-out at that dose, not a potency): 58%
Beside the measured number, compound 4's estimate is 33 percentage points below it, and the stated range covers the measured number.
By their numbers in this assay, from the lowest: compounds 3 and 1 (each within the scatter of the next); then compound 4; then compound 2.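

In this assay, the amide-type nitrogen whose other neighbours are the carbonyl carbon and a saturated chain carbon proves to be a responsive position: ethyl in place of hydrogen gives a number 37 percentage points higher from compound 1 to compound 4 (beyond the scatter) and so raises the read-out rather than losing it. The earlier compounds shown here showed a large step only on the other amide-type nitrogen, with a number 79 percentage points higher from compound 1 to compound 2 (beyond the scatter), while hydroxy on the saturated ring gave a number 3 percentage points lower from compound 1 to compound 3 (within the scatter); large steps are now seen at both amide-type nitrogens of the shared core. No measurement in hand accounts for the rise at this nitrogen.

As far as these compounds go, it remains open how the read-out depends on the group at this nitrogen, and methyl, a longer chain such as propyl, or a chain ending in an amine or a carboxylic acid would each test whether ethyl is a special case or part of a trend. Also open, from the compounds shown here alone, is whether ethyl at this nitrogen and cyclopropyl on the other amide-type nitrogen would combine in one compound, and how either change behaves at other doses.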